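The compounds below may be only part of what the source reports. "The series", "measured", "known", "first", "only" and "open" are said of these compounds alone.

For the measured compounds named here, in a functional assay on SF-295 cells (Homo sapiens) for inhibition, read by sulforhodamine B assay, with a stated time of 48 h (a higher number here means a weaker inhibitor of growth, a lower number a stronger inhibitor of growth), compound 2, with structure `CN1CCN(CCCOc2cccc3nc(Nc4ccc(F)c(F)c4)ccc23)CC1`, gives 4640 nM, the highest of the two numbers measured so far. Going by the values given here, its nearest neighbour is compound 1, with structure `CN1CCN(CCCOc2cccc3nc(Nc4ccc(Cl)c(F)c4)ccc23)CC1`, which in this assay gives 1790 nM; the single measured step, a 2.6-fold higher number from compound 1 to compound 2 (0.41 log units; beyond the scatter), is the only guide available. Compound 3, with structure `CN1CCN(CCCOc2cccc3nc(Nc4cc(Cl)cc(Cl)c4)ccc23)CC1`, has not yet been measured. It differs from compound 2 by 3,5-dichlorophenyl in place of 3,4-difluorophenyl on a nitrogen on an aromatic ring. Among the compounds with values here, the one measured step bears on this change because a 2.6-fold higher number from compound 1 to compound 2 (0.41 log units; beyond the scatter) shows that swapping chloro for fluoro raised the number modestly, and here both fluorines give way to chlorines, although their positions on the ring also shift, which no measured pair covers. A modest lowering of the number is therefore expected, roughly a 2.4-fold lower number from compound 2 to compound 3 (0.39 log units; beyond the scatter). Compound 3 is estimated at 1900 nM, with a range from 700 nM to 5500 nM.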

Compound 3, concentration for 50% growth inhibition: 1720 nM
Beside the measured number, compound 3's estimate is 1.1-fold (0.04 log units) above it; the measured number falls inside the stated range.
By their numbers in this assay, from the lowest: compounds 3 and 1 (each within the scatter of the next); then compound 2.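

In this assay, 3,5-dichlorophenyl on this nitrogen gives a 2.7-fold lower number from compound 2 to compound 3 (0.43 log units; beyond the scatter), so a change of the whole substituted phenyl group moves the number about as far as the earlier single swap of chloro for fluoro. Against the group with one chlorine, it gives a 1.0-fold lower number from compound 1 to compound 3 (0.02 log units; within the scatter), so the second chlorine, in this arrangement, brings no readable change, and among these three compounds only compound 2, the one without chlorine, stands apart. Nothing measured here explains these shifts.

The compounds shown leave open whether the number follows the chlorines themselves or where they sit on the ring, a question that 3,4-dichlorophenyl on this nitrogen would help to settle. From the compounds shown here alone, how a phenyl carrying a methoxy group or a nitrile would fare at this place is also open.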